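The source may hold more compounds than are shown below. What is called first, only, known or untested is meant among the compounds shown, and "the series" means these compounds.

In an in vitro ADME assay on microsomes from liver (Homo sapiens) for metabolic stability, tested at 1 uM (on this read-out lower numbers stand for a shorter-lived compound and higher numbers for a longer-lived compound), compound 1 `COc1cccc(CN2C(=O)C(C3=NS(=O)(=O)c4cc(NS(C)(=O)=O)ccc4N3)=C(O)[C@@H]3[C@H]4CC[C@H](C4)[C@@H]32)c1` gives > 1 h, which is a limit of the assay and not a number. Compound 2 `CS(=O)(=O)Nc1ccc2c(c1)S(=O)(=O)N=C(C1=C(O)[C@@H]3[C@H]4CC[C@H](C4)[C@@H]3N(Cc3ccc(F)c(Cl)c3)C1=O)N2` gives > 1 h, again only a limit. Going by the values given here, compound 3 `CC(C)CCN1C(=O)C(C2=NS(=O)(=O)c3cc(NS(C)(=O)=O)ccc3N2)=C(O)[C@@H]2[C@H]3CC[C@H](C3)[C@@H]21` gives 0.617 h, the only true number in this small set.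

Compound 4 `CC(C)CCN1C(=O)C(C2=NS(=O)(=O)c3cc(NS(C)(=O)=O)ccc3N2)=C(O)[C@@H]2[C@@H]3CC[C@@H](C3)[C@@H]21` has the same atoms and bonds as compound 3 and differs only in configuration as drawn: the two compounds have the same atoms and bonds and differ only in configuration as drawn: 2 of 4 stereo elements differ; a stereocentre at a saturated ring carbon is drawn S in compound 3 and R in compound 4; a stereocentre at a saturated ring carbon is drawn R in compound 3 and S in compound 4.

Three measured steps involve these compounds: an at least 1.6-fold lower number from compound 1 to compound 3 (0.20 log units; that floor lies within the scatter), an at least 1.6-fold lower number from compound 2 to compound 3 (0.20 log units; that floor lies within the scatter) and a step that the two limits leave unreadable from compound 1 to compound 2. The first two have floors that lie within the scatter. All three exchange the group on the saturated chain carbon bound to the amide-type nitrogen in a ring, and none changes configuration alone. They therefore give no measured size for this change, and no step beyond the scatter is expected in this assay, in either direction.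

The expected step is a 1.0-fold lower number from compound 3 to compound 4 (0.01 log units; within the scatter). For compound 4, the estimated half-life is 0.6 h, with an expected range from 0.3 h to 1 h.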

Compound 4, half-life: 0.3 h
Compound 4: the middle estimate sits 2.0-fold (0.30 log units) above what was measured; the range from low to high includes it.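

In this assay, a change of configuration alone now has a measured size: a 2.1-fold lower number from compound 3 to compound 4 (0.31 log units; beyond the scatter). The earlier steps shown here all exchanged the group on the saturated chain carbon, so none of them could separate configuration from a change of group, and here the comparison is clean: the fact that compounds 3 and 4 differ only in the configuration as drawn. With the isobutyl group in place, the two stereocentres at saturated ring carbons therefore cannot be treated as interchangeable in this assay, although the step is modest.

As far as these compounds go, whether the same inversion matters with 3-methoxyphenyl or 3-chloro-4-fluorophenyl in place of isobutyl stays open, and any comparison of those two groups cannot be read: the limit of > 1 h in this assay, at which 2 of the 4 values shown sit. Also open, from the compounds shown here alone, are which of the two stereocentres carries the step and how a longer chain or a carboxylic acid in place of isobutyl would behave in either configuration.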